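Benzamide in place of benzophenone on the ester side chain

The compounds below may be only part of what the source reports. "The series", "measured", "known", "first", "only" and "open" are said of these compounds alone.

Working notes on a small set of compounds sharing one core, all tested in an assay on isolated protein for binding affinity to Type-2 angiotensin II receptor (Homo sapiens); a lower number here means a stronger inhibitor, a higher number a weaker inhibitor. Compound 1 `CCCc1nc(CC)c(C(=O)OCc2ccccc2OC)n1Cc1ccc(-c2ccccc2S(=O)(=O)NC(=O)OCCC(C)C)cc1F` gives 1 nM. Compound 3 `CCCCN(Cc1ccccc1)C(=O)C#CCOC(=O)c1c(CC)nc(CCC)n1Cc1ccc(-c2ccccc2-c2nn[nH]n2)cc1` gives 400 nM. Compound 2 `CCCc1nc(CC)c(C(=O)OCc2ccc(C(=O)c3ccccc3)cc2)n1Cc1ccc(-c2ccccc2-c2nn[nH]n2)cc1` gives 2000 nM, the highest number of the three; compound 3 stands closest to it with a lower number, and compound 1 stands furthest with a far lower number, both gaps beyond the scatter.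

Compound 4 `CCCCN(Cc1ccccc1)C(=O)c1ccc(COC(=O)c2c(CC)nc(CCC)n2Cc2ccc(-c3ccccc3-c3nn[nH]n3)cc2)cc1` is the unmeasured partner of compound 2. The change is benzyl(butyl)amino in place of phenyl on a carbonyl carbon; in words, benzyl(butyl)amino in place of phenyl on a carbonyl carbon. Going by the values given here, no measured pair shows this exact step. The same benzyl(butyl)amino carbonyl appears in compound 3, where this assay gives 400 nM, a lower number than compound 2 shows, though the rest of the side chain differs there. The step from compound 2 to compound 4 is therefore expected to give a lower number, moderately beyond the scatter, a 3.3-fold lower number from compound 2 to compound 4 (0.52 log units; beyond the scatter). Compound 4 is estimated at 600 nM, with a range of 150 nM to 2500 nM.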

Compound 4, half-maximal inhibitory concentration: 200 nM
Compound 4: the middle estimate sits 3.0-fold (0.48 log units) above what was measured; low and high end bracket the measured number.
By their numbers in this assay, from the lowest: compound 1; then compounds 4 and 3 (each within the scatter of the next); then compound 2.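

Working from the one matched pair in the set, a 10-fold lower number from compound 2 to compound 4 (1.00 log units; beyond the scatter) is read in this assay when benzyl(butyl)amino replaces phenyl on a carbonyl carbon whose other neighbour is an aromatic carbon. The earlier compounds shown here could not isolate this position, and the step now shows that it responds to the change and accepts the larger group, which keeps one six-membered aromatic ring and adds a nitrogen and further carbon. No measurement at hand gives a reason for this step.

Going by these compounds, it remains open whether the butyl chain, the benzyl group or both carry the step, and how a smaller amine such as dimethylamino or a longer chain on the nitrogen would read at this carbonyl. A carboxylic acid in place of the whole amide is equally unresolved.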